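The compounds below may be only part of what the source reports. "The series", "measured", "known", "first", "only" and "open" are said of these compounds alone.

Three compounds that share one core were tested in a functional assay on MDA-MB-231 cells (Homo sapiens) for antiproliferative activity, read by MTT assay, with a stated time of 72 h; a lower number here means a stronger inhibitor, a higher number a weaker inhibitor. Compound 1 (`CCCn1ccnc1-c1cc(OC)c(OC)c(OC)c1`) gives > 100000 nM, which is a limit of the assay and not a number. Compound 2 (`COc1cc(-c2nccn2CC(C)C)cc(OC)c1OC`) gives > 100000 nM, again a limit. Compound 3 (`COc1cc(-c2nccn2Cc2ccccc2)cc(OC)c1OC`) gives > 100000 nM, also a limit. Compound 3 therefore has no exact position and stands level with the other two: the limit of > 100000 nM in this assay, at which 3 of the 3 values shown sit.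

The next change leads to compound 4 (`COc1cc(-c2nccn2-c2ccc(F)cc2)cc(OC)c1OC`), with 4-fluorophenyl in place of benzyl on an aromatic nitrogen. The earlier changes offer little guidance. They are a step that the two limits leave unreadable from compound 1 to compound 2, a step that the two limits leave unreadable from compound 1 to compound 3 and a step that the two limits leave unreadable from compound 2 to compound 3. None of these steps has a readable size, and none swaps benzyl for 4-fluorophenyl. A large gain therefore has no support, although a limit leaves room for a modest move towards stronger inhibition. The expected change is small, and it is estimated as an at least 2.0-fold lower number from compound 3 to compound 4 (0.30 log units; that floor lies within the scatter). The assay may well report only a limit again. If a number does appear, the estimate for compound 4 is 50000 nM, with an expected range from 10000 nM to 100000 nM.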

Compound 4, half-maximal inhibitory concentration: 38400 nM
The estimate for compound 4 lay 1.3-fold (0.11 log units) above the measured number; low and high end bracket the measured number.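

Within the data shown here, compound 4 is the first compound here to give a number rather than a limit in this assay, so the group on the aromatic nitrogen can shift the read-out into a measurable range; the steps among compound 1, compound 2 and compound 3 cannot be read and could not show this. Putting 4-fluorophenyl in place of benzyl gives an at least 2.6-fold lower number from compound 3 to compound 4 (0.41 log units; beyond the scatter), even though the two groups have the same heavy-atom count, while 4-fluorophenyl in place of isobutyl gives an at least 2.6-fold lower number from compound 2 to compound 4 (0.41 log units; beyond the scatter) and 4-fluorophenyl in place of propyl gives an at least 2.6-fold lower number from compound 1 to compound 4 (0.41 log units; beyond the scatter). All three steps are floors rather than full sizes, because the starting compound of each pair stands at a limit: the limit of > 100000 nM in this assay, at which 3 of the 4 values shown sit.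

Benzyl and 4-fluorophenyl differ both in the fluorine and in how the aromatic ring is joined to the nitrogen, so the compounds shown do not tell which of the two differences matters, and plain phenyl on that nitrogen would help to separate them. Going by these compounds, it also remains open how this assay would read with a different group on that ring in place of the fluorine, such as methoxy or an amine.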